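Iodo in Place of Ethynyl on the Shared Core

A few compounds are considered here, and "the series" means these few. Any claim that something is new, unique, unknown or untested is made for them only; others in the source may bear on it.

Compound 1, `COc1ncnc2c1c(-c1ccsc1)cn2[C@@H]1O[C@H](CO)[C@@H](O)[C@H]1O`, gives 3350 nM in a functional assay on HeLa S3 cells (Homo sapiens) for antiproliferative activity, read by XTT assay, with a stated time of 72 h; on this read-out higher numbers stand for weaker inhibition and lower numbers for stronger inhibition.
Compound 2, `C#Cc1cn([C@@H]2O[C@H](CO)[C@@H](O)[C@H]2O)c2ncnc(OC)c12`, gives 1730 nM in this assay.

For the measured compounds named here, compound 2 holds the lowest of the two numbers, yet its only neighbour is compound 1, and the step of a 1.9-fold lower number from compound 1 to compound 2 (0.29 log units; within the scatter) lies within the scatter, so the two cannot be ordered. Compound 3, `COc1ncnc2c1c(I)cn2[C@@H]1O[C@H](CO)[C@@H](O)[C@H]1O`, differs from compound 2 in one place: iodo in place of ethynyl on an aromatic carbon. Going by the values given here, the single measured step touches the same aromatic carbon, where ethynyl replaced thiophen-3-yl without a change beyond the scatter. Among the compounds with values here, no measured step involves iodo. Within the data shown here, with only that one small step to lean on, the expected change for compound 3 is none beyond the scatter, a 1.2-fold higher number from compound 2 to compound 3 (0.06 log units; within the scatter). Among the measured compounds shown here, compound 3 is therefore estimated at 2000 nM, with a range from 800 nM to 5000 nM, the width reflecting the single reference step.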

Compound 3, half-maximal inhibitory concentration: 14300 nM
For compound 3 the middle estimate is 7.2-fold (0.85 log units) below the measured one, outside the stated range (above it).
By their numbers in this assay, from the lowest: compounds 2 and 1 (each within the scatter of the next); then compound 3.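

Iodo on this aromatic carbon moves the number beyond the scatter in this assay: the change gives an 8.3-fold higher number from compound 2 to compound 3 (0.92 log units; beyond the scatter) when iodo replaces ethynyl, and a 4.3-fold higher number from compound 1 to compound 3 (0.63 log units; beyond the scatter) when iodo replaces thiophen-3-yl. The earlier step, between thiophen-3-yl and ethynyl, stayed within the scatter, so it could have suggested that this carbon tolerates any group. Compound 3 shows that the read-out does depend on what sits here, and that two quite different groups, one a ring and one a triple-bonded chain, can match each other while iodo gives a clearly weaker result.

Going by these compounds, whether an amine, a methyl group, a bromo group or a longer carbon chain on this carbon would fall with iodo or with the other two groups stays open. Nothing measured in the data shown accounts for the higher number with iodo.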